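The source may report more compounds than this note shows. Statements on the series, on what has been measured and on what is new or still open speak of the compounds shown alone.

Working notes on the series.

Compound 1 `COc1ccc(/C=C/C2(C)C=CC(=O)O2)c(OC)c1OC` gives 71500 nM in a functional assay on UACC-62 cells (Homo sapiens) for inhibition, read by sulforhodamine B assay, with a stated time of 48 h; a higher number here means a weaker inhibitor of growth, a lower number a stronger inhibitor of growth. Compound 2 `COc1c(O)ccc(/C=C/C2(C)C=CC(=O)O2)c1OC` gives 24600 nM in this assay, and compound 3 `CC1(/C=C/c2cccc(O)c2)C=CC(=O)O1` gives 108000 nM. Compound 4 `COc1cccc(/C=C/C2(C)C=CC(=O)O2)c1` has not yet been measured in this assay.

From compound 2 to compound 1 the change is methyl in place of hydrogen on an oxygen on an aromatic ring; the measured step is a 2.9-fold higher number from compound 2 to compound 1 (0.46 log units; beyond the scatter). From compound 3 to compound 4 the change is methyl in place of hydrogen on an oxygen on an aromatic ring. Both changes sit at the same kind of place, on an oxygen on an aromatic ring whose other neighbour is aromatic carbon, so this is the same kind of change, made on a different core; the difference between the cores of compound 3 and compound 2 is not broken down here.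

For compound 4 a step of about a 1.9-fold higher number from compound 3 to compound 4 (0.27 log units; within the scatter) is expected in this assay, resting on the measured step of a 2.9-fold higher number from compound 2 to compound 1 (0.46 log units; beyond the scatter) applied to compound 3 at 108000 nM. The estimate for compound 4 is therefore 200000 nM, with a plausible range from 90000 nM to 450000 nM.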

Compound 4, concentration for total growth inhibition: 55800 nM
Beside the measured number, compound 4's estimate is 3.6-fold (0.55 log units) above it; the measured number lies below the stated range.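

In this assay, the change from hydroxy to methoxy gives a 1.9-fold lower number from compound 3 to compound 4 (0.29 log units; within the scatter), so on this core the step stays within the scatter. The same change does not carry over with one size from one core to the other: the same change on two cores in this assay, a 2.9-fold higher number (0.46 log units; beyond the scatter) from compound 2 to compound 1 and a 1.9-fold lower number (0.29 log units; within the scatter) from compound 3 to compound 4, 5.6-fold (0.75 log units) apart, beyond the scatter of two such steps. For these two pairs the step therefore differs with the core, but the pairs do not show which feature of the cores is responsible, and they give no rule for any further core.

On these data alone, it remains open whether a third core would give a step like that on the core of compound 2 or that on the core of compound 3. As far as these compounds go, it also remains open how a longer chain, such as ethyl, would behave on that oxygen in place of methyl.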